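Fluoro in Place of Chloro on Compound 2

The source may hold more compounds than are shown below. What is called first, only, known or untested is meant among the compounds shown, and "the series" means these compounds.

In a functional assay on L1210 cells (Mus musculus) for antiproliferative activity, read by cell counting, with a stated time of 2 days (on this read-out lower numbers stand for stronger inhibition and higher numbers for weaker inhibition), compound 1 `COc1cc(C(=O)c2sc(Nc3ccccc3)nc2N)cc(OC)c1OC` gives 18 nM. Compound 2 `COc1ccc(C(=O)c2sc(Nc3ccc(Cl)cc3)nc2N)cc1` yields no number in this assay, only the limit > 10000 nM. Compound 3 `COc1ccc(C(=O)c2sc(Nc3ccc(F)cc3)nc2N)cc1` follows from compound 2 through one change, fluoro in place of chloro on an aromatic carbon, para to a large group. Among the compounds with values here, no measured step yet shows what this change does, so little movement is expected. The expected step, a number no higher from compound 2 to compound 3 (the limit leaves the size open), stays within the usual scatter, with no direction foreseen. For compound 3 the estimated value is 10000 nM, with an expected range of 3000 nM to 30000 nM.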

Compound 3, half-maximal inhibitory concentration: > 10000 nM
Compound 3: no number, only a limit (the forecaster's own chance of this, stated with the estimate: 70%); the middle value lies on the limit itself.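

Compound 2 and compound 3 each give only a limit in this assay, so no step between them can be read: the limit of > 10000 nM in this assay, at which 2 of the 3 values shown sit.

On these data alone, what fluoro in place of chloro on an aromatic carbon does in this assay stays open.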